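A few compounds are considered here, and "the series" means these few. Any claim that something is new, unique, unknown or untested is made for them only; others in the source may bear on it.

Measured compounds in a functional assay on HL-60 cells (Homo sapiens) for cytotoxicity, read by WST assay, with a stated time of 48 h; on this read-out higher numbers stand for weaker inhibition and lower numbers for stronger inhibition:
- compound 1, `Oc1ccccc1/C=C/C[C@H]1C[C@@H]([C@@H](O)c2ccccc2)CO[C@@H]1c1ccccc1`, gives 10800 nM.
- compound 2, `C=CC[C@H]1C[C@@H]([C@@H](O)c2ccccc2)CO[C@@H]1c1ccccc1`, gives 36000 nM.
- compound 3, `COc1ccc(/C=C/C[C@@H]2C[C@H]([C@H](O)c3ccc(OC)c(OC)c3)CO[C@H]2c2ccc(OC)c(OC)c2)cc1OC`, has no result in this assay: its entry reads "not determined" (no result reported).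

Compound 1 holds the lowest of the two numbers in this assay. Within the data shown here, the one measured step, a 3.3-fold higher number from compound 1 to compound 2 (0.52 log units; beyond the scatter), shows that losing the aryl-bearing chain costs a modest amount. Compound 4, `O=[N+]([O-])c1cccc(/C=C/C[C@H]2C[C@@H]([C@@H](O)c3ccccc3)CO[C@@H]2c2ccccc2)c1`, differs from compound 1 by 3-nitrophenyl in place of 2-hydroxyphenyl on a double-bonded chain carbon bound to a double-bonded chain carbon. Among the measured compounds shown here, no measured step swaps one aryl for another here, so the only relevant guidance is that the aryl itself matters modestly; for a change that keeps the ring and alters its substituent, no step beyond the scatter is expected in this assay, so a 1.1-fold higher number from compound 1 to compound 4 (0.05 log units; within the scatter) is the expected outcome. Compound 4 is therefore estimated at 12000 nM, within 4000 nM to 40000 nM.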

Compound 4, half-maximal inhibitory concentration: 6350 nM
Beside the measured number, compound 4's estimate is 1.9-fold (0.28 log units) above it; measured number inside the range.
By their numbers in this assay, from the lowest: compounds 4 and 1 (each within the scatter of the next); then compound 2.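

In this assay, the exchange of 2-hydroxyphenyl for 3-nitrophenyl on a double-bonded chain carbon bound to a double-bonded chain carbon gives a 1.7-fold lower number from compound 1 to compound 4 (0.23 log units; within the scatter) and so stays within the scatter. At this position, the aryl substituent can therefore differ in identity and placement with no step beyond the scatter, even with 0 hydrogen-bond donors in the entering group against 1 in the leaving group. No evidence on the cause of this outcome is available.

Open, from the compounds shown here alone, is whether an aryl ring bearing an amine or a carboxylic acid would also stay within the scatter of compound 1.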